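A Shorter Chain on a Weakly Inhibiting Fused Core

This account rests on a few compounds, and the source may have more. Where it says the series, first, only, none or still open, it means among the compounds named here.

Of the compounds shown here, three of a shared core have been tested in a functional assay for inhibition, with Homo sapiens as the target; a lower number here means a stronger inhibitor, a higher number a weaker inhibitor. Compound 1 `CCCc1nc(C)c2c(C(C)C)nnc(O)n12` reaches only a limit of the assay, > 48000 nM. Compound 3 `Cc1nc(C)n2c(=O)n(C)ncc12` likewise reaches only a limit, > 48000 nM. Compound 2 `CCc1nnc(O)n2c(C(C)CC)nc(C)c12` is the one compound for which a number is shown: in this assay compound 2 gives 45000 nM, a weak inhibition. It stands alone, the other two values being limits of the assay (the limit of > 48000 nM in this assay, at which 2 of the 3 values shown sit).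

Compound 4 `CCc1nnc(O)n2c(C)nc(C)c12` has not yet been measured in this assay. It differs from compound 2 in one place: methyl in place of sec-butyl on an aromatic carbon. For the measured compounds named here, no measured step between compounds differing in a single place is available, so the size of the step can only be estimated. The other two compounds sit at a limit (the limit of > 48000 nM in this assay, at which 2 of the 3 values shown sit). Given that compound 2 gives 45000 nM, the expected step of a 1.3-fold higher number from compound 2 to compound 4 (0.12 log units; within the scatter) is small, within the scatter or slightly toward weaker inhibition. Compound 4 is therefore expected to give about 60000 nM, in a range from 20000 nM to 200000 nM, and the assay would more likely than not report only a limit.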

Compound 4, half-maximal inhibitory concentration: > 48000 nM
Compound 4 ended at the assay's limit; the forecaster's own chance of this, stated with the estimate: 65%; the middle value is on the limit's open side.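

For the compounds shown here, this result gives the first step between compounds that differ in one place, on the aromatic carbon of the five-membered ring: methyl in place of sec-butyl gives an at least 1.0-fold higher number from compound 2 to compound 4 (0.02 log units; that floor lies within the scatter) in this assay. In that assay compound 4 gives > 48000 nM, which is a limit and not a number, so the step is only a floor and its full size cannot be read. The methyl compound thus shows no sign of stronger inhibition, and compound 2 remains the only compound with a number, the others sitting at one limit: the limit of > 48000 nM in this assay, at which 3 of the 4 values shown sit.

As far as these compounds go, it stays open whether sec-butyl contributes anything to the weak inhibition of compound 2. Also open, from the compounds shown here alone, is how an amine, a carboxylic acid or a longer chain on this carbon would read in this assay.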